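Changing the phenyl group on an amide-type nitrogen

A few compounds are considered here, and "the series" means these few. Any claim that something is new, unique, unknown or untested is made for them only; others in the source may bear on it.

In a functional assay on HT-29 cells (Homo sapiens) for cytotoxicity, read by MTT assay, with a stated time of 72 h (on this read-out lower numbers stand for stronger inhibition and higher numbers for weaker inhibition), compound 2 (`O=C(CN1CCN(c2nnc(Cc3ccncc3)c3ccccc23)CC1)Nc1ccc(F)c(C(F)(F)F)c1`) gives 1110 nM and compound 1 (`Cc1ccc(NC(=O)CN2CCN(c3nnc(Cc4ccncc4)c4ccccc34)CC2)c(C)c1`) gives 1930 nM and these two numbers lie within the usual scatter of each other. Going by the values given here, compound 2 therefore stands level with its only measured neighbour.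

Compound 3 (`Cc1ccc(F)cc1NC(=O)CN1CCN(c2nnc(Cc3ccncc3)c3ccccc23)CC1`) carries 5-fluoro-2-methylphenyl in place of 4-fluoro-3-(trifluoromethyl)phenyl on an amide-type nitrogen, while the shared core stays as it is. The counted difference reads: 5-fluoro-2-methylphenyl in place of 4-fluoro-3-(trifluoromethyl)phenyl on an amide-type nitrogen and it is not yet known how this exchange reads out.

Among the compounds with values here, one measured step bears on it. There, 4-fluoro-3-(trifluoromethyl)phenyl replaced 2,4-dimethylphenyl at the same place, and the result was a 1.7-fold lower number from compound 1 to compound 2 (0.24 log units; within the scatter) for a change that likewise exchanged one substituted phenyl for another. That single pair is thin evidence, but it gives no reason to expect a step beyond the scatter in this assay here. The estimated step is a 1.4-fold higher number from compound 2 to compound 3 (0.13 log units; within the scatter) and no clear direction is expected. For compound 3 the estimated value is 1500 nM with an expected range from 700 nM to 3500 nM in this series.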

Compound 3, half-maximal inhibitory concentration: 470 nM
Compound 3: the middle estimate sits 3.2-fold (0.50 log units) above what was measured; the measured number lies below the stated range.
By their numbers in this assay, from the lowest: compound 3; then compounds 2 and 1 (each within the scatter of the next).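

In this assay, going by these compounds alone, the exchange at this amide-type nitrogen gives the first steps beyond the scatter: a 2.4-fold lower number from compound 2 to compound 3 (0.37 log units; beyond the scatter), and a 4.1-fold lower number from compound 1 to compound 3 (0.61 log units; beyond the scatter). This shows that the choice of substituted phenyl at this place can move the number, which compound 1 and compound 2 alone could not show, since their values lie within the scatter of each other. Neither shared feature alone goes with the lower number, as compound 1 also carries a 2-methyl group and compound 2 also carries a ring fluorine, and nothing available explains why this particular combination reads lower.

Going by these compounds, how an unsubstituted phenyl, a fluorophenyl with no methyl, or a phenyl bearing an amine or a carboxylic acid would read at this place remains open, so the separate contributions of the methyl and the fluorine cannot be told apart. Whether the lower number of compound 3 would also appear on cells other than HT-29 is likewise left open by the compounds shown.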